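A few compounds are considered here, and "the series" means these few. Any claim that something is new, unique, unknown or untested is made for them only; others in the source may bear on it.

Compound 1 `CC(C)(C)c1cc(NC(=O)Nc2ccc(NC(=O)c3ccc(OC4CCN(C(C)(C)C)CC4)cn3)cc2)no1` 2670 ng.h/mL
Compound 2 `CC(C)(C)c1cc(NC(=O)Nc2ccc(NC(=O)c3ccc(OC4CCN(C5CC5)CC4)cn3)cc2)no1` 4930 ng.h/mL
Compound 3 `CC1(C)CC(Oc2ccc(C(=O)Nc3ccc(NC(=O)Nc4cc(C(C)(C)C)on4)cc3)nc2)CC(C)(C)N1` 1280 ng.h/mL

In an ADME assay on the whole organism (plasma, strain Sprague-Dawley) for pharmacokinetics, with Rattus norvegicus as the target, read by LC-MS, at a dose of 10 mg/kg by the oral route (a higher number here means more compound in the circulation at the dose given, a lower number less compound in the circulation), compound 3 stands lowest of the three numbers, and its steps to both others lie beyond the scatter. Compound 4 `CCN1CCC(Cc2ccc(C(=O)Nc3ccc(NC(=O)Nc4cc(C(C)(C)C)on4)cc3)nc2)CC1` differs from compound 3 as follows ((1-ethylpiperidin-4-yl)methyl in place of (2,2,6,6-tetramethylpiperidin-4-yl)oxy on an aromatic carbon). Within the data shown here, two measured steps bear on this change (a 2.1-fold lower number from compound 1 to compound 3 (0.32 log units; beyond the scatter)) and (a 3.9-fold lower number from compound 2 to compound 3 (0.59 log units; beyond the scatter)). Both are modest, and both end at the 2,2,6,6-tetramethylpiperidin-4-yl group that compound 4 gives up. The swap of cyclopropyl for tert-butyl on the ring nitrogen (a 1.8-fold higher number from compound 1 to compound 2 (0.27 log units; within the scatter)) stays within the scatter. Among the measured compounds shown here, no measured compound carries the (1-ethylpiperidin-4-yl)methyl group, so the range stays wide. A modest rise is expected, estimated as (a 2.0-fold higher number from compound 3 to compound 4 (0.29 log units; within the scatter)). For compound 4 the estimated value is 2500 ng.h/mL with an expected range from 800 ng.h/mL to 6500 ng.h/mL in this assay.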

Compound 4, area under the concentration-time curve: 707 ng.h/mL
For compound 4 the middle estimate is 3.5-fold (0.55 log units) above the measured one; measured number below the stated range.
By their numbers in this assay, from the lowest: compounds 4 and 3 (each within the scatter of the next); then compounds 1 and 2 (each within the scatter of the next).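

In this assay, the (1-ethylpiperidin-4-yl)methyl group does not separate from the (2,2,6,6-tetramethylpiperidin-4-yl)oxy group at this aromatic carbon (a 1.8-fold lower number from compound 3 to compound 4 (0.26 log units; within the scatter)). Set against the piperidinyloxy groups with a substituent on the ring nitrogen, the same group falls beyond the scatter, both for 1-cyclopropyl (a 7.0-fold lower number from compound 2 to compound 4 (0.84 log units; beyond the scatter)) and for 1-(tert-butyl) (a 3.8-fold lower number from compound 1 to compound 4 (0.58 log units; beyond the scatter)). Nothing at hand explains these steps.

Still open, going by these compounds, is how the methylene link and the ethyl on the ring nitrogen each contribute, since the two change together here. A (1-cyclopropylpiperidin-4-yl)methyl group would separate them.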